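Lengthening the hydroxymethyl arm of compound 1

A few compounds are considered here, and "the series" means these few. Any claim that something is new, unique, unknown or untested is made for them only; others in the source may bear on it.

For the measured compounds named here, compound 1, `CCCCCCCOc1ccc(CCC(N)(CO)CO)cc1`, sits at the low end of the three numbers measured so far: in a functional assay on the whole organism (spleen, spleen) with Rattus norvegicus as the target (a higher number here means that more compound is needed for the effect, a lower number that less compound is needed), compound 1 gives 0.014 mg/kg. Compound 2, `CCCCCCCOc1ccc(CCC(N)(CC)CO)cc1`, gives 0.044 mg/kg, and compound 3, `CCCCCCCOc1ccc(CC[C@@](N)(CO)CCC)cc1`, gives 4.4 mg/kg. The step of a 3.1-fold higher number from compound 1 to compound 2 (0.50 log units; beyond the scatter) shows that swapping one hydroxyl-bearing arm for a methyl costs only modestly, whereas the step of a 310-fold higher number from compound 1 to compound 3 (2.50 log units; beyond the scatter) shows a far larger loss when the arm is both stripped of oxygen and lengthened. The step of a 100-fold higher number from compound 2 to compound 3 (2.00 log units; beyond the scatter) points the same way.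

Compound 4, `CCCCCCCOc1ccc(CC[C@@](N)(CO)CCO)cc1`, differs from compound 1 as follows: a group of 7 heavy atoms (4 carbon, 1 nitrogen, 2 oxygen; no ring) in place of a group of 6 heavy atoms (3 carbon, 1 nitrogen, 2 oxygen; no ring), on a saturated chain carbon, two bonds along the chain from an aromatic carbon. Here the oxygen is kept and the arm grows by one carbon. Because the oxygen-free swap a 3.1-fold higher number from compound 1 to compound 2 (0.50 log units; beyond the scatter) was modest and the larger loss in a 310-fold higher number from compound 1 to compound 3 (2.50 log units; beyond the scatter) came with an oxygen-free, longer arm, a modest rise in the dose is expected for compound 4, with a 7.1-fold higher number from compound 1 to compound 4 (0.85 log units; beyond the scatter) as the likely size. The estimate for compound 4 in this assay is 0.1 mg/kg, expected to fall between 0.025 mg/kg and 0.5 mg/kg.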

Compound 4, dose for 50% inhibition: 0.018 mg/kg
For compound 4 the middle estimate is 5.6-fold (0.74 log units) above the measured one, and the stated range ends above it.
By their numbers in this assay, from the lowest: compounds 1 and 4 (each within the scatter of the next); then compound 2; then compound 3.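

In this assay, the arm can gain a carbon while keeping its hydroxy with no change beyond the scatter, at a 1.3-fold higher number from compound 1 to compound 4 (0.11 log units; within the scatter). At the position three bonds along the chain from an amine nitrogen, hydroxy in place of methyl gives a 240-fold lower number from compound 3 to compound 4 (2.39 log units; beyond the scatter), and the longer hydroxy-bearing arm also compares well with the arm of compound 2, at a 2.4-fold lower number from compound 2 to compound 4 (0.39 log units; beyond the scatter). Methyl in place of hydroxy therefore costs far more on the longer arm than on the shorter one: the same change on two cores in this assay, a 3.1-fold higher number (0.50 log units; beyond the scatter) from compound 1 to compound 2 and a 240-fold higher number (2.39 log units; beyond the scatter) from compound 4 to compound 3, 78-fold (1.89 log units) apart, beyond the scatter of two such steps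

The compounds shown leave open whether an amine or a carboxylic acid could stand in place of the hydroxy on the longer arm, and whether a still longer chain carrying a hydroxy would keep the number this low. They also leave open how the opposite arrangement at the defined stereocentre of compound 4 would read.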